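Para substituent exchange in a phthalide writhing series

This account rests on a few compounds, and the source may have more. Where it says the series, first, only, none or still open, it means among the compounds named here.

Measured so far in a functional assay on the whole organism (Abdomen, strain Swiss) for inhibition, with Mus musculus as the target, in the writhing test, with stated times of 60 min and 20 min; a higher number here means that more compound is needed for the effect, a lower number that less compound is needed:
- compound 1 `O=C(CC1OC(=O)c2ccccc21)c1ccccc1` gives 63.5 umol/kg
- compound 2 `COc1ccc(C(=O)CC2OC(=O)c3ccccc32)cc1` gives 52.7 umol/kg
- compound 3 `Cc1ccc(C(=O)CC2OC(=O)c3ccccc32)cc1` gives 42.5 umol/kg

Compound 3 carries the lowest of the three numbers, yet a 1.5-fold lower number from compound 1 to compound 3 (0.17 log units; within the scatter) and a 1.2-fold lower number from compound 2 to compound 3 (0.09 log units; within the scatter) are both within the scatter, so the three compounds are not separated by these data. The third exchange, a 1.2-fold lower number from compound 1 to compound 2 (0.08 log units; within the scatter), is within the scatter as well.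

Compound 4 `O=C(CC1OC(=O)c2ccccc21)c1ccc(Cl)cc1` is the next member. The change from compound 3 is chloro in place of methyl on an aromatic carbon. All three steps seen so far concern a group at this same place, para to a large group, and none of them moved the number beyond the scatter. For the measured compounds named here, they are the only steps that bear on the present change, and on their basis no step beyond the scatter is expected in this assay in either direction: the expected step is a 1.1-fold higher number from compound 3 to compound 4 (0.02 log units; within the scatter). Compound 4 is therefore estimated at 45 umol/kg, with a range of 25 umol/kg to 80 umol/kg.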

Compound 4, dose for 50% inhibition: 33.7 umol/kg
Compound 4: the middle estimate sits 1.3-fold (0.13 log units) above what was measured; the range from low to high includes it.
By their numbers in this assay, from the lowest: compounds 4, 3, 2 and 1 (each within the scatter of the next).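

In this assay chloro, the only halogen shown at this place para to a large group, stays within the scatter of each of the other three groups: a 1.3-fold lower number from compound 3 to compound 4 (0.10 log units; within the scatter), a 1.6-fold lower number from compound 2 to compound 4 (0.19 log units; within the scatter) and a 1.9-fold lower number from compound 1 to compound 4 (0.28 log units; within the scatter). Hydrogen, methoxy, methyl and chloro at this place are therefore not separated by this read-out, so the flat picture from the earlier compounds now extends to a fourth group and to a halogen in place of methyl. Nothing at hand explains this flat picture.

Open, from the compounds shown here alone, is whether an amine, a carboxylic acid or a longer chain at this place would move the number beyond the scatter. Also open, going by these compounds, is how the number responds to exchanges elsewhere on the shared core, since all four compounds differ only at this one place.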